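The source may hold more compounds than are shown below. What is called first, only, known or untested is meant among the compounds shown, and "the series" means these compounds.

Working notes on the series.

All three measured compounds share one core and differ at two places: the aryl group on the pyridine and the alkoxy group. Compound 1 `CCOc1nc(-c2nc3ccccc3n2C)cc(-c2ccc(Cl)cc2)c1C#N` gives 293000 nM in a functional assay on aorta (Rattus norvegicus, strain Wister); on this read-out lower numbers stand for stronger inhibition and higher numbers for weaker inhibition. Compound 2 `CCOc1nc(-c2nc3ccccc3n2C)cc(-c2cccs2)c1C#N` gives 249000 nM in this assay. Compound 3 `COc1nc(-c2nc3ccccc3n2C)cc(-c2ccc(C)o2)c1C#N` gives 283000 nM in this assay. On these numbers compound 3 sits with the other two: its gap to compound 1 and its gap to compound 2 both fall within the scatter, so no order among the three can be read from the data.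

Compound 4 `CCOc1nc(-c2nc3ccccc3n2C)cc(-c2ccc(C)o2)c1C#N` is not yet measured. It differs from compound 3 by methyl in place of hydrogen on a saturated chain carbon bound to an oxygen on an aromatic ring. Going by the values given here, the only measured single-place step, a 1.2-fold lower number from compound 1 to compound 2 (0.07 log units; within the scatter), concerns the aryl group and not the alkoxy group, so no measured step speaks directly to the change from compound 3 to compound 4. That step was within the scatter, and the three measured values as a whole spread across less than the scatter.

The expectation for the step of a 1.0-fold lower number from compound 3 to compound 4 (0.00 log units; within the scatter) in this assay is therefore that it stays within the scatter, in neither direction. Compound 4 is estimated at 280000 nM in this assay, with an expected range from 140000 nM to 560000 nM.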

Compound 4, half-maximal inhibitory concentration: 336000 nM
Compound 4: the middle estimate sits 1.2-fold (0.08 log units) below what was measured; the range from low to high includes it.
By their numbers in this assay, from the lowest: compounds 2, 3, 1 and 4 (each within the scatter of the next).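

Going by these compounds alone, the change from methoxy to ethoxy, with the 5-methylfuran-2-yl group held constant, gives the first measured step at the alkoxy position: in this assay it reads a 1.2-fold higher number from compound 3 to compound 4 (0.07 log units; within the scatter) and so leaves the value within the scatter. With the ethoxy group held constant, the aryl position now has three measured groups, and neither 5-methylfuran-2-yl step separates from the scatter: one reads a 1.3-fold higher number from compound 2 to compound 4 (0.13 log units; within the scatter) and the other reads a 1.1-fold higher number from compound 1 to compound 4 (0.06 log units; within the scatter) in the same assay. Thus neither the added methyl on the saturated chain carbon bound to an oxygen on an aromatic ring nor either replacement of the aryl group moves the value beyond the scatter, and no evidence is available that would account for this flat picture.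

The alkoxy position is covered only by methoxy and ethoxy, so a longer chain such as butoxy, or a chain ending in an amine or a carboxylic acid, remains an open question. The nitrile is common to all four compounds, so replacing it with an amide or a carboxylic acid also remains untested in the compounds shown here.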